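The source may hold more compounds than are shown below. What is called first, only, known or untested is meant among the compounds shown, and "the series" means these compounds.

Measured so far:
compound 1 `CN(C)CCn1c(N)c(-c2nc3ccccc3[nH]2)c2nc(C#N)c(C#N)nc21`: 6340 nM
compound 2 `CN(C)CCCn1c(N)c(-c2nc3ccccc3[nH]2)c2nc(C#N)c(C#N)nc21`: 1730 nM

In a functional assay on K562 cells (Homo sapiens) for antiproliferative activity, read by MTT assay, with a stated time of 48 h (on this read-out higher numbers stand for weaker inhibition and lower numbers for stronger inhibition), compound 2 stands as the lowest of the two numbers shown, with compound 1 the only neighbour. Among the measured compounds shown here, the one measured step, a 3.7-fold lower number from compound 1 to compound 2 (0.56 log units; beyond the scatter), lengthened the chain and left the amine untouched. Compound 3 `N#Cc1nc2c(-c3nc4ccccc4[nH]3)c(N)n(CCCN3CCCCC3)c2nc1C#N` carries a different kind of change: piperidin-1-yl in place of dimethylamino on a saturated chain carbon, three bonds along the chain from an aromatic nitrogen. For the measured compounds named here, no measured step swaps one amine for another, so none bears directly on this change; the expectation is therefore a step of a 1.2-fold lower number from compound 2 to compound 3 (0.06 log units; within the scatter), within the scatter. Compound 3 is estimated at 1500 nM, with a range from 500 nM to 4500 nM.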

Compound 3, half-maximal inhibitory concentration: 3460 nM
Beside the measured number, compound 3's estimate is 2.3-fold (0.36 log units) below it, within the range that was stated.
By their numbers in this assay, from the lowest: compounds 2, 3 and 1 (each within the scatter of the next, the first and the last beyond it).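

In this assay, 3-(piperidin-1-yl)propyl in place of 3-(dimethylamino)propyl gives a 2.0-fold higher number from compound 2 to compound 3 (0.30 log units; within the scatter), so at this position, closing the amine into a six-membered ring makes no difference that can be told from the scatter. Moving from 2-(dimethylamino)ethyl to the piperidine on the longer chain gives a 1.8-fold lower number from compound 1 to compound 3 (0.26 log units; within the scatter), which also cannot be told from the scatter. No measurement here explains these numbers. Still open, on these data alone, is whether a morpholin-4-yl or pyrrolidin-1-yl group, or a 4-(dimethylamino)butyl chain, would move the number beyond the scatter.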